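This account rests on a few compounds, and the source may have more. Where it says the series, first, only, none or still open, it means among the compounds named here.

Compound 1, `COc1cccc(CNCCCNc2ccnc3cc(Oc4ccc(F)cc4)ccc23)c1O`: in an ADME assay for permeability, using PAMPA, with a stated time of 30 min, at pH 7.4 (on this read-out higher numbers stand for higher permeability and lower numbers for lower permeability), compound 1 gives 317 10^-6 cm/s.
Compound 2, `CCC(CC)c1ccc2c(NCCCNCc3cccc(OC)c3O)ccnc2c1`: compound 2 gives 23 10^-6 cm/s.
Compound 3, `COc1cccc(CNCCCNc2ccnc3cc(Cc4ccc(C#N)cc4)ccc23)c1O`: compound 3 gives 23 10^-6 cm/s.

Compound 3 sits level with compound 2, the two together forming the lowest pair of the three numbers, as the step of no change at the digits printed from compound 2 to compound 3 (within the scatter) shows. Against compound 1 the gap is wide: a 14-fold lower number from compound 1 to compound 3 (1.14 log units; beyond the scatter), matched by a 14-fold lower number from compound 1 to compound 2 (1.14 log units; beyond the scatter).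

Compound 4, `COc1cccc(CNCCCNc2ccnc3cc(Cc4cccc(C(F)(F)F)c4)ccc23)c1O`, differs from compound 3 in one place:

3-(trifluoromethyl)phenyl in place of 4-cyanophenyl on a saturated chain carbon bound to an aromatic carbon

Among the compounds with values here, none of the measured steps alters a substituent on the phenyl ring of the benzyl group itself. The two large steps, a 14-fold lower number from compound 1 to compound 2 (1.14 log units; beyond the scatter) and a 14-fold lower number from compound 1 to compound 3 (1.14 log units; beyond the scatter), each exchange the whole group on the aromatic carbon of the core, while no change at the digits printed from compound 2 to compound 3 (within the scatter) shows that a pentan-3-yl and a 4-cyanobenzyl give the same reading. Within the data shown here, the data therefore offer no step of the same kind as the one from compound 3 to compound 4, and the modest exchange of one ring substituent for another gives no reason to expect a movement beyond the scatter in this assay.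

Compound 4 is thus expected to stay close to compound 3, with an estimated step of a 1.2-fold higher number from compound 3 to compound 4 (0.09 log units; within the scatter). The estimate for compound 4 is 28 10^-6 cm/s, with a range from 10 10^-6 cm/s to 75 10^-6 cm/s.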

Compound 4, apparent permeability: 23 10^-6 cm/s
Beside the measured number, compound 4's estimate is 1.2-fold (0.09 log units) above it; measured number inside the range.
By their numbers in this assay, from the lowest: compounds 2, 3 and 4 (each within the scatter of the next); then compound 1.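

In this assay, the exchange of 4-cyanophenyl for 3-(trifluoromethyl)phenyl on a saturated chain carbon bound to an aromatic carbon is the first change shown within the benzyl group itself, and it gives no change at the digits printed from compound 3 to compound 4 (within the scatter), even though a nitrile gives way to a trifluoromethyl group and the count of hydrogen-bond acceptors in the group falls from 1 to 0. The wider comparisons place 3-(trifluoromethyl)benzyl at the same level as pentan-3-yl, with no change at the digits printed from compound 2 to compound 4 (within the scatter), and leave 4-fluorophenoxy as the only group shown that stands apart, with a 14-fold lower number from compound 1 to compound 4 (1.14 log units; beyond the scatter). Nothing at hand explains why these groups read as they do.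

The compounds shown leave open whether the high reading of compound 1 goes with the oxygen that joins its ring to the shared core or with the 4-fluorophenyl ring, a question that a 4-fluorobenzyl group on the same aromatic carbon would help to settle. From the compounds shown here alone, it also remains open whether the level held by compound 2, compound 3 and compound 4 would persist with a carboxylic acid or an amine on the benzyl ring.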